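Replacing the methoxypropynyl group with an aromatic ring

The source may hold more compounds than are shown below. What is called first, only, known or untested is meant among the compounds shown, and "the series" means these compounds.

Compound 1 `COCC#Cc1cc(C(O)(C(F)(F)F)C(F)(F)F)cnc1N1CCN(S(=O)(=O)c2ccc(N)nc2)CC1` carries a 3-methoxyprop-1-yn-1-yl group on the shared core. Going by the values given here, in an ADME assay (liver) for metabolic stability, with Liver microsome (Rattus norvegicus) as the target, using microsomes and NADPH, with a stated time of 30 min, tested at 1 uM (a lower number here means slower removal, a higher number faster removal of the compound), compound 1 gives 399 mL.min-1.g-1, the highest of the two numbers measured so far. Among the compounds with values here, compound 2 `Nc1ccc(S(=O)(=O)N2CCN(c3ncc(C(O)(C(F)(F)F)C(F)(F)F)cc3-c3ccncc3)CC2)cn1` gives 31 mL.min-1.g-1 in this assay, and the step of a 13-fold lower number from compound 1 to compound 2 (1.11 log units; beyond the scatter) is the one measured change that bears on the present question. Compound 3 `COc1cncc(-c2cc(C(O)(C(F)(F)F)C(F)(F)F)cnc2N2CCN(S(=O)(=O)c3ccc(N)nc3)CC2)c1` is not yet measured. It differs from compound 1 in one place: 5-methoxypyridin-3-yl in place of 3-methoxyprop-1-yn-1-yl on an aromatic carbon. Within the data shown here, as in the measured step, a six-membered aromatic ring with one nitrogen enters where the 3-methoxyprop-1-yn-1-yl group leaves, so a large drop in this assay is expected, though the single measured example gives no guide to how the added methoxy group shifts it. The expected step is a 7.3-fold lower number from compound 1 to compound 3 (0.86 log units; beyond the scatter). Compound 3 is therefore estimated at 55 mL.min-1.g-1, within a range from 22 mL.min-1.g-1 to 140 mL.min-1.g-1.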

Compound 3, intrinsic clearance in microsomes: 58 mL.min-1.g-1
Compound 3: middle estimate off by 1.1-fold (0.02 log units), on the low side, within the range that was stated.
By their numbers in this assay, from the lowest: compounds 2 and 3 (each within the scatter of the next); then compound 1.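

In this assay a second aromatic ring at this position, 5-methoxypyridin-3-yl, also gives a lower number than the 3-methoxyprop-1-yn-1-yl group, with a 6.9-fold lower number from compound 1 to compound 3 (0.84 log units; beyond the scatter), so the fall is no longer tied to pyridin-4-yl alone. Between the two pyridine substituents there is a 1.9-fold higher number from compound 2 to compound 3 (0.27 log units; within the scatter), so the added methoxy group and the different ring attachment, which change together in this pair, do not separate the two compounds here. No measurement on hand gives a reason for either step.

Still open, going by these compounds, is whether the fall follows from the aromatic ring entering or from the triple bond leaving. A plain phenyl ring, a saturated piperidine ring or a propyl ether chain without the triple bond at this position would help to separate the two.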